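The compounds below may be only part of what the source reports. "The series", "measured", "known", "first", "only" and "open" are said of these compounds alone.

Compound 1 `Fc1ccc(-c2cn3ccnc3c(-c3ccc4ncn(C5CCCCC5)c4c3)n2)cc1`: 20.4%
Compound 2 `c1cn2cc(-c3ccsc3)nc(-c3ccc4ncn(C5CCCCC5)c4c3)c2n1`: 14.3%
Compound 3 `Fc1ccccc1-c1cn2ccnc2c(-c2ccc3ncn(C4CCCCC4)c3c2)n1`: 16.3%

These three compounds share a common core and differ only in the aromatic group attached to it. Measured in a functional assay on SR cells (Homo sapiens) for inhibition, read by sulforhodamine B assay, with a stated time of 48 h, tested at 10 uM (on this read-out lower numbers stand for less inhibition and higher numbers for more inhibition at the one concentration tested (going by the name of the read-out)), compound 3 gives 16.3%, which is the second highest of the three numbers; the values of compound 1 and compound 2 lie within the scatter of it on either side. Compound 4 `c1csc(-c2cn3ccnc3c(-c3ccc4ncn(C5CCCCC5)c4c3)n2)c1` is not yet measured and differs from compound 3 by one change: thiophen-2-yl in place of 2-fluorophenyl on an aromatic carbon.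

Among the compounds with values here, two measured steps bear on this change, since both exchange a fluorophenyl group for a thiophenyl group or the reverse: a number 6.1 percentage points lower from compound 1 to compound 2 (within the scatter) and a number 2 percentage points higher from compound 2 to compound 3 (within the scatter). Neither moved the read-out beyond the scatter, so an exchange of this kind in this assay is expected to have little effect. Compound 4 carries a thiophenyl attached through a different ring carbon than compound 2, which adds some uncertainty, but no shift beyond the scatter is expected. The estimated step is a number 0.3 percentage points lower from compound 3 to compound 4 (within the scatter). Compound 4 is therefore expected to give about 16%, in the range from 8% to 26%.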

Compound 4, a percentage reported as inhibition, at one concentration (the size of the read-out at that concentration, not a potency): 27.2%
Compound 4: middle estimate off by 11.2 percentage points, on the low side, and the stated range ends below it.
By their numbers in this assay, from the lowest: compounds 2, 3, 1 and 4 (each within the scatter of the next, the first and the last beyond it).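

In this assay, within the data shown here, the point of attachment of the thiophene ring matters at this position: thiophen-2-yl in place of thiophen-3-yl gives a number 12.9 percentage points higher from compound 2 to compound 4 (beyond the scatter), the first step in this set that clearly exceeds the usual variation. Thiophen-2-yl in place of 2-fluorophenyl gives a number 10.9 percentage points higher from compound 3 to compound 4 (beyond the scatter), while thiophen-2-yl in place of 4-fluorophenyl gives a number 6.8 percentage points higher from compound 1 to compound 4 (within the scatter), so the outcome depends on which aryl group is replaced. Nothing presented here explains these differences.

Every group shown at this position is a single aromatic ring, so it remains open how an amine, a carboxylic acid or a longer chain would behave there. Each result comes from one concentration, which leaves the potency of these compounds unknown.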